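This account rests on a few compounds, and the source may have more. Where it says the series, first, only, none or still open, it means among the compounds named here.

In an ADME assay for permeability, using PAMPA (on this read-out lower numbers stand for lower permeability and higher numbers for higher permeability), compound 2 (`O=C(Nc1c(Cl)cc([N+](=O)[O-])cc1Cl)c1cc(Cl)ccc1O`) gives 53 10^-6 cm/s and so sits within the scatter of compound 3 (`O=C(Nc1ccncc1Cl)c1cc(Cl)ccc1O`), which gives 31 10^-6 cm/s on the same read-out. Compound 1 (`O=C(Nc1ccc([N+](=O)[O-])cc1)c1cc(Cl)ccc1O`) gives 127 10^-6 cm/s and lies above compound 2 by more than the scatter.

Compound 4 (`O=C(Nc1c(Cl)cc(F)cc1Cl)c1cc(Cl)ccc1O`) differs from compound 2 in one place. The change is fluoro in place of nitro on an aromatic carbon and amounts to fluoro in place of nitro on an aromatic carbon, meta to two chloro groups and para to a large group.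

Within the data shown here, no measured pair isolates this swap, so the size of the step in this assay has no direct precedent. With only the spread from compound 3 at 31 10^-6 cm/s to compound 1 at 127 10^-6 cm/s as a guide, a modest upward move is expected, not clearly beyond the scatter. The expected change is a 1.3-fold higher number from compound 2 to compound 4 (0.12 log units; within the scatter) and remains an estimate. For compound 4 the estimated value is 70 10^-6 cm/s with an expected range from 30 10^-6 cm/s to 160 10^-6 cm/s on this read-out.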

Compound 4, apparent permeability in the ADME assay: 25 10^-6 cm/s
Beside the measured number, compound 4's estimate is 2.8-fold (0.45 log units) above it, outside the stated range (below it).
By their numbers in the ADME assay, from the lowest: compounds 4, 3 and 2 (each within the scatter of the next, the first and the last beyond it); then compound 1.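

Among these compounds, at this position, meta to two chloro groups and para to a large group, fluoro in place of nitro gives the first single-change reading: in the ADME assay the swap gives a 2.1-fold lower number from compound 2 to compound 4 (0.33 log units; beyond the scatter) on this one pair. In a physicochemical assay for solubility (a lower number here means a less soluble compound, a higher number a more soluble compound), compound 4 gives > 49 ug/mL which is a limit of the assay and not a number. With compound 2 at 53 ug/mL in the physicochemical assay the step cannot be read: the limit of > 49 ug/mL in the physicochemical assay, at which 1 of the 2 values shown sits.

What the compounds shown leave open is whether an amine or a carboxylic acid at this position would give a number in the ADME assay on the same side of compound 2. Also open, going by these compounds, is whether the same swap gives a step of this size without the two chloro groups, the arrangement compound 1 carries with its nitro.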